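Extending the piperidine linker on compound 3

This account rests on a few compounds, and the source may have more. Where it says the series, first, only, none or still open, it means among the compounds named here.

Compound 3 `O=C(C1CCNCC1)N1CCC(NS(=O)(=O)c2cc(S(=O)(=O)c3ccccc3)ccc2C(F)(F)F)CC1` gives 120 nM in an assay on isolated protein for displacement of a labelled ligand from secreted frizzled-related protein 1 (Homo sapiens), read by fluorescence polarization, with a stated time of 30 min (on this read-out higher numbers stand for weaker inhibition and lower numbers for stronger inhibition), the second highest of the three numbers recorded. Compound 1 `O=C(O)c1cccc(S(=O)(=O)N2CCC(NS(=O)(=O)c3cc(S(=O)(=O)c4ccccc4)ccc3C(F)(F)F)CC2)c1` gives 20 nM, and the step of a 6.0-fold higher number from compound 1 to compound 3 (0.78 log units; beyond the scatter) shows how far compound 3 lags behind it. Within the data shown here, compound 2 `CC(C)(C)OC(=O)N1CCC(CC(=O)N2CCC(NS(=O)(=O)c3cc(S(=O)(=O)c4ccccc4)ccc3C(F)(F)F)CC2)CC1` gives 490 nM; no single step connects compound 2 with compound 3, so their two values are simply set side by side.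

Compound 4 `O=C(CC1CCNCC1)N1CCC(NS(=O)(=O)c2cc(S(=O)(=O)c3ccccc3)ccc2C(F)(F)F)CC1` is not yet measured. It differs from compound 3 by (piperidin-4-yl)methyl in place of piperidin-4-yl on a carbonyl carbon. Among the measured compounds shown here, no measured pair isolates this one-atom extension of the linker, so no step can be read directly. Compound 2 carries the same extended linker but also a tert-butoxycarbonyl group on the ring nitrogen, and its value stands higher than that of compound 3; compound 4 keeps the free ring nitrogen of compound 3. For the measured compounds named here, the expectation is therefore a small weakening for compound 4, a 1.7-fold higher number from compound 3 to compound 4 (0.22 log units; within the scatter), within the uncertainty of a change that has no direct precedent here. Compound 4 is estimated at 200 nM in this assay, expected to lie between 70 nM and 600 nM.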

Compound 4, half-maximal inhibitory concentration in the secreted frizzled-related protein 1 assay: 100 nM
For compound 4 the middle estimate is 2.0-fold (0.30 log units) above the measured one; the measured number falls inside the stated range.
By their numbers in the secreted frizzled-related protein 1 assay, from the lowest: compound 1; then compounds 4 and 3 (each within the scatter of the next); then compound 2.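

On the carbonyl carbon, (piperidin-4-yl)methyl in place of piperidin-4-yl makes no difference beyond the scatter in the secreted frizzled-related protein 1 assay (a 1.2-fold lower number from compound 3 to compound 4 (0.08 log units; within the scatter)), and a physicochemical assay for solubility (on this read-out lower numbers stand for lower solubility and higher numbers for higher solubility), shows the same for this change (no change at the digits printed from compound 3 to compound 4 (within the scatter); compound 3 gives 100000 nM and compound 4 gives 100000 nM). With the linker held constant, hydrogen in place of tert-butoxycarbonyl on the ring nitrogen gives a step beyond the scatter in the secreted frizzled-related protein 1 assay (a 4.9-fold lower number from compound 2 to compound 4 (0.69 log units; beyond the scatter)), so that group, not the extended linker, accounts for this gap. The (3-carboxyphenyl)sulfonyl group also keeps its advantage in the secreted frizzled-related protein 1 assay when ((piperidin-4-yl)methyl)carbonyl replaces it (a 5.0-fold higher number from compound 1 to compound 4 (0.70 log units; beyond the scatter)).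

No evidence at hand explains these steps. On these data alone, it remains open whether a longer chain or a carboxylic acid on that carbonyl carbon would close the gap to compound 1.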